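Capping groups on the amine nitrogen: a flat series so far

A few compounds are considered here, and "the series" means these few. Any claim that something is new, unique, unknown or untested is made for them only; others in the source may bear on it.

In a functional assay for inhibition, with Homo sapiens as the target (on this read-out higher numbers stand for weaker inhibition and lower numbers for stronger inhibition), compound 1 (`CC(C)CS(=O)(=O)N[C@@H](CNC(=O)c1ccc2c(c1)C(=O)N(CCC1CCNCC1)C2)C(=O)O`) gives 9 nM, compound 2 (`CCCCCC(=O)N[C@@H](CNC(=O)c1ccc2c(c1)C(=O)N(CCC1CCNCC1)C2)C(=O)O`) gives 13 nM, and compound 3 (`O=C(NCc1ccccc1)N[C@@H](CNC(=O)c1ccc2c(c1)C(=O)N(CCC1CCNCC1)C2)C(=O)O`) gives 10 nM. Compound 3 thus stands within the scatter of both others. Compound 4 (`CCCCNS(=O)(=O)N[C@@H](CNC(=O)c1ccc2c(c1)C(=O)N(CCC1CCNCC1)C2)C(=O)O`) carries butylsulfamoyl in place of benzylcarbamoyl on an amine nitrogen. Three measured steps exchange the group at this place: a 1.4-fold higher number from compound 1 to compound 2 (0.16 log units; within the scatter), a 1.1-fold higher number from compound 1 to compound 3 (0.05 log units; within the scatter) and a 1.3-fold lower number from compound 2 to compound 3 (0.11 log units; within the scatter). All three stay within the scatter, so no step beyond the scatter is expected in this assay. The estimated step is a 1.1-fold higher number from compound 3 to compound 4 (0.04 log units; within the scatter), with no clear direction expected. The expected value for compound 4 is 11 nM, with an estimated range of 5 nM to 25 nM.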

Compound 4, half-maximal inhibitory concentration: 19 nM
Beside the measured number, compound 4's estimate is 1.7-fold (0.24 log units) below it; the range from low to high includes it.
By their numbers in this assay, from the lowest: compounds 1, 3, 2 and 4 (each within the scatter of the next, the first and the last beyond it).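

Butylsulfamoyl gives the first step at this amine nitrogen that leaves the scatter in this assay: a 2.1-fold higher number from compound 1 to compound 4 (0.32 log units; beyond the scatter), a modest step with butylamino in place of isobutyl on a sulfonyl sulfur. The other two new steps, a 1.9-fold higher number from compound 3 to compound 4 (0.28 log units; within the scatter) and a 1.5-fold higher number from compound 2 to compound 4 (0.16 log units; within the scatter), stay within the scatter, so the four capping groups still span only a narrow range. No evidence on the origin of the modest step is at hand.

Open, as far as these compounds go, is whether a phenyl ring or a morpholine on the sulfonyl sulfur, in place of butylamino, would move the number further from that of compound 1.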